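The compounds below may be only part of what the source reports. "The series", "measured", "known", "first", "only" and "open" are said of these compounds alone.

Measured in a functional assay on HCT-116 cells (Homo sapiens) for inhibition, read by luminescence and resazurin assay, with a stated time of 3 days; a higher number here means a weaker inhibitor, a lower number a stronger inhibitor:
- Compound 1 `CNc1nc(NCc2ccc(C(=O)NC3CCN(Cc4ccc(F)cc4)CC3)cc2)c2cc(C)ccc2n1`: 1200 nM
- Compound 2 `CNc1ncc(C)c(NCc2ccc(NC(=O)c3ccc(F)cc3)cc2)n1`: > 20000 nM

Within the data shown here, compound 1 holds the only number so far in this assay. Compound 2 has only a limit of the assay, > 20000 nM, and not a number.

The next step leads to compound 3 `Cc1ccc2nc(N3CCNC(C)C3)nc(NCc3ccc(C(=O)NC4CCN(Cc5ccc(F)cc5)CC4)cc3)c2c1`, which has not yet been measured. It keeps the rest of compound 1 and carries 3-methylpiperazin-1-yl in place of methylamino on an aromatic carbon, between two ring nitrogen atoms (3-methylpiperazin-1-yl in place of methylamino on an aromatic carbon).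

Among the measured compounds shown here, no measured step in this small set covers a replacement at that place, so the expectation rests only on compound 1 at 1200 nM and on the structural change itself. A moderate move towards stronger inhibition is expected, somewhat beyond the usual scatter, though an outcome within the scatter remains quite possible. The expected step is a 2.4-fold lower number from compound 1 to compound 3 (0.38 log units; beyond the scatter). For compound 3 the estimated value is 500 nM, with an expected range of 120 nM to 2200 nM.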

Compound 3, half-maximal inhibitory concentration: 2000 nM
Compound 3: middle estimate off by 4.0-fold (0.60 log units), on the low side, and the stated range covers the measured number.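

In this assay, replacing methylamino with 3-methylpiperazin-1-yl on the aromatic carbon between two ring nitrogen atoms gives a 1.7-fold higher number from compound 1 to compound 3 (0.22 log units; within the scatter). This place in the core therefore takes a six-membered non-aromatic ring with 2 hetero atoms, a much larger group by heavy-atom count, with no change beyond the scatter, and neither a gain nor a loss can be claimed for the exchange. Compound 2 holds only a limit and not a number, and it differs from the other compounds in more than one place, so it adds nothing on this position: the limit of > 20000 nM in this assay, at which 1 of the 3 values shown sits.

The single replacement leaves open how much the ring and its methyl group each contribute, since they enter together and the step shows only their combined result. Piperazin-1-yl without the methyl, morpholine or dimethylamino at this place would separate those contributions and show whether the ring amine hydrogen matters to the number in this assay.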